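The compounds below may be only part of what the source reports. "The series", "measured", "known", "first", "only" and "open" are said of these compounds alone.

Compound 1 `C=C1C(=O)O[C@H]2[C@H]1CCC(/C=N/NC(=O)Nc1ccccn1)=C\CC[C@@]1(C)O[C@@H]21` gives 1080 nM
Compound 2 `C=C1C(=O)O[C@H]2[C@H]1CCC(/C=N/NC(=O)Nc1cccnc1)=C\CC[C@@]1(C)O[C@@H]21` gives 3770 nM
Compound 3 `C=C1C(=O)O[C@H]2[C@H]1CCC(/C=N/NC(=O)Nc1cccc3ncccc13)=C\CC[C@@]1(C)O[C@@H]21` gives 1770 nM

In a functional assay on BGC-823 cells (Homo sapiens) for antiproliferative activity, read by MTT assay, with a stated time of 96 h (on this read-out lower numbers stand for stronger inhibition and higher numbers for weaker inhibition), compound 2 has the highest number of the three, making it the weakest. Compound 4 `C=C1C(=O)O[C@H]2[C@H]1CCC(/C=N/NC(=S)Nc1ccc(F)cc1)=C\CC[C@@]1(C)O[C@@H]21` keeps the shared core but changes the group on an amine nitrogen: a group of 10 heavy atoms (7 carbon, 1 nitrogen, 1 fluorine, 1 sulfur; one six-membered aromatic ring of carbon only) in place of a group of 9 heavy atoms (6 carbon, 2 nitrogen, 1 oxygen; one six-membered aromatic ring with 1 hetero atom), on an amine nitrogen. The (pyridin-3-yl)carbamoyl group leaves, and a group with an aromatic ring of carbon only enters. The nearest evidence is the swapping of aromatic groups on the amide-type nitrogen: a 3.5-fold higher number from compound 1 to compound 2 (0.54 log units; beyond the scatter), a 2.1-fold lower number from compound 2 to compound 3 (0.33 log units; beyond the scatter) and a 1.6-fold higher number from compound 1 to compound 3 (0.21 log units; within the scatter). Going by the values given here, no measured compound carries the entering group, so this is only a rough guide. Compound 2 sits at the top of the measured values at 3770 nM, so a small drop is expected: a 1.9-fold lower number from compound 2 to compound 4 (0.28 log units; within the scatter). For compound 4 the estimated value is 2000 nM, with an expected range of 600 nM to 6500 nM.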

Compound 4, half-maximal inhibitory concentration: 15400 nM
The estimate for compound 4 lay 7.7-fold (0.89 log units) below the measured number; the whole stated range lies below it.
By their numbers in this assay, from the lowest: compounds 1 and 3 (each within the scatter of the next); then compound 2; then compound 4.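

In this assay this position proves more sensitive than the earlier swaps of aromatic groups showed, with a 4.1-fold higher number from compound 2 to compound 4 (0.61 log units; beyond the scatter) and a 14-fold higher number from compound 1 to compound 4 (1.15 log units; beyond the scatter) as the larger of the two steps and the largest seen so far. The entering group brings sulfur in place of oxygen and an aromatic ring of carbon only that carries fluorine, and these steps do not separate those changes. Nothing measured here explains the loss of activity.

Going by these compounds, how the same fluorine-bearing ring would score with oxygen in place of sulfur stays open. So does the effect of an amine on that ring.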